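Shared-core series: working notes toward compound 4

The source may hold more compounds than are shown below. What is called first, only, known or untested is meant among the compounds shown, and "the series" means these compounds.

Measured compounds in a functional assay on Jurkat cells (Homo sapiens) for cytotoxicity, read by MTT assay, with a stated time of 2 days; on this read-out higher numbers stand for weaker inhibition and lower numbers for stronger inhibition:
compound 1 `Cc1ccc(-c2nc3ccc(F)cc3s2)cc1N` gives > 50000 nM, a limit of the assay.
compound 2 `Cc1ccc(-c2nc3ccccc3s2)cc1N` gives > 50000 nM, a limit of the assay.
compound 3 `COc1ccc2nc(-c3ccc(NC(=O)NCc4ccccc4)cc3)sc2c1` gives > 50000 nM, a limit of the assay.

Every value shown sits at the limit of > 50000 nM in this assay, at which 3 of the 3 values shown sit; none is a number. Within the data shown here, the single change between measured compounds, hydrogen in place of fluoro on an aromatic carbon, is a step that the two limits leave unreadable from compound 1 to compound 2 and cannot be read. Compound 3 therefore stands where each measured compound stands, at the limit, with no number placed on it in this assay.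

Compound 4 `COc1ccc2nc(-c3ccc(NC(=O)C4CC4)cc3)sc2c1` is the next compound. It differs from compound 3 by cyclopropyl in place of benzylamino on a carbonyl carbon. No measured step touches this position, and the one step available is unreadable, so nothing shown bears on it in size or direction. The expectation in this assay rests only on the three limits.

The expected step is a number no higher from compound 3 to compound 4 (the limit leaves the size open), that is none beyond the scatter, with another limit the most likely outcome. Compound 4 is estimated at 50000 nM, with a range from 20000 nM to 200000 nM.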

Compound 4, half-maximal inhibitory concentration: > 50000 nM
Compound 4 was reported as a limit; the forecaster's own chance of this, stated with the estimate: 85%; the middle value sits exactly at the limit.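

Compound 4 gives > 50000 nM, a limit of the assay. No new step can be read, as the change from compound 3 to compound 4 joins two limits, and every value in the series remains one: the limit of > 50000 nM in this assay, at which 4 of the 4 values shown sit. The compounds shown leave open how large either step is and whether any change in the series gives a readable number.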